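Two Diaryl Ether Esters at the Assay Limit

This account rests on a few compounds, and the source may have more. Where it says the series, first, only, none or still open, it means among the compounds named here.

Measured so far in a functional assay on HL-60 cells (Homo sapiens) for antiproliferative activity; a lower number here means a stronger inhibitor, a higher number a weaker inhibitor
- Compound 1 `CCOC(=O)c1ccc(Oc2ccc(F)c(F)c2)cc1` gives > 30000 nM (a limit)
- Compound 2 `CCOC(=O)c1ccc(Oc2ccc(OC)c(F)c2)cc1O` gives > 30000 nM (a limit)

Compound 2 stands at > 30000 nM, which is a limit of the assay and not a number. For the measured compounds named here, the whole measured record is the limit of > 30000 nM in this assay, at which 2 of the 2 values shown sit, so there is no graded potency to work from, and no step between measured compounds is available to size a structural change.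

The next compound is compound 3 `CCOC(=O)c1ccc(Oc2ccc(F)c(F)c2)cc1O`. It carries fluoro in place of methoxy on an aromatic carbon, ortho to a fluoro group and para to a large group (fluoro in place of methoxy on an aromatic carbon). The rest of the structure of compound 2 is kept.

In this assay no shift beyond the usual scatter is expected, and no direction can be favoured. This expectation rests on compound 2 at > 30000 nM, a limit. The expected change, a number no higher from compound 2 to compound 3 (the limit leaves the size open), is estimated to be small. For compound 3 the estimated value is 30000 nM, with an expected range of 10000 nM to 50000 nM.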

Compound 3, half-maximal inhibitory concentration: > 30000 nM
Compound 3: only a limit was reported; the forecaster's own chance of this, stated with the estimate: 70%; the middle value sits exactly at the limit.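

In this assay compound 3 gives > 30000 nM and this is a limit, not a number. The steps from compound 1 and from compound 2 to compound 3 cannot be read, and the record holds no graded value: the limit of > 30000 nM in this assay, at which 3 of the 3 values shown sit. The compounds shown leave open whether any change on the shared core affects antiproliferative potency.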